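From Pyridin-3-yl to 2,5-Difluorophenyl: An Unmeasured Step

The source may report more compounds than this note shows. Statements on the series, on what has been measured and on what is new or still open speak of the compounds shown alone.

Compound 1 `COc1ccc(-c2sc(N)c(C(=O)c3ccc(Cl)cc3)c2C)cc1` gives 1% in an assay on CHO cells for displacement of a labelled ligand from adenosine receptor A3 (Homo sapiens), read by scintillation counting, tested at 10 uM; on this read-out lower numbers stand for less inhibition and higher numbers for more inhibition at the one concentration tested (going by the name of the read-out).
Compound 2 `Cc1sc(N)c(C(=O)c2ccc(Cl)cc2)c1-c1ccccc1` gives 1% in this assay.
Compound 3 `CC(C)(C)Cc1c(-c2cccnc2)sc(N)c1C(=O)c1ccc(Cl)cc1` gives 1% in this assay.

All three measured compounds sit at the same reading, and compound 3 stands level with compound 1 and compound 2 at the digits shown; the differences between them fall within the scatter of repeated measurements, so no order among them can be claimed. No pair of these compounds differs in a single place, so no measured step is available to lean on.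

Compound 4 `CC(C)(C)Cc1c(-c2cc(F)ccc2F)sc(N)c1C(=O)c1ccc(Cl)cc1` is the one not yet measured. It differs from compound 3 by 2,5-difluorophenyl in place of pyridin-3-yl on an aromatic carbon.

Among the compounds with values here, with every measured compound at the floor of the read-out and no single-point step to guide the expectation, compound 4 is expected to remain near where compound 3 lies, with a step no larger than the scatter, as a number 2 percentage points higher from compound 3 to compound 4 (within the scatter).

For compound 4, the expected reading in this assay is estimated at 3%, within a range from -5% to 15%.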

Compound 4, a percentage reported as inhibition, at one concentration (the size of the read-out at that concentration, not a potency): 1%
The estimate for compound 4 lay 2 percentage points above the measured number; low and high end bracket the measured number.
By their numbers in this assay, from the lowest: compounds 1, 2, 3 and 4 (each within the scatter of the next).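

In this assay, within the data shown here, putting 2,5-difluorophenyl in place of pyridin-3-yl on the aromatic carbon next to the ring sulfur gives no change at the digits printed from compound 3 to compound 4 (within the scatter) and so provides the first reading of a change in a single place. At this position, with the neopentyl group held constant, exchanging the nitrogen-containing ring for the fluorinated carbon ring does not separate the two compounds, and neither lifts the reading off the low level shared by the whole set. Nothing measured here explains this result.

Because both readings are so low, the step cannot show whether this position matters when the reading is higher. Also open, on these data alone, is whether an amine or a carboxylic acid on this ring, or a longer chain in place of neopentyl, would give a different reading.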